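The source may hold more compounds than are shown below. What is called first, only, known or untested is meant among the compounds shown, and "the series" means these compounds.

Compound 1 `Oc1cc(-c2ccc(Cl)cc2)nc2ncccc12`: 5890 nM
Compound 2 `Cc1ccnc2nc(-c3ccc(Cl)cc3)cc(O)c12`: 759 nM
Compound 3 `COc1cccc(-c2cc(O)c3c(C)ccnc3n2)c1`: < 10 nM

Of the compounds shown here, three of one shared core have been measured in a functional assay on MDA-MB-435 cells (Homo sapiens); a lower number here means a stronger inhibitor of growth, a higher number a weaker inhibitor of growth. Compound 1 gives 5890 nM and compound 2 gives 759 nM. For compound 3 this assay returns only a limit, < 10 nM. The difference between the core of compound 2 and the core of compound 3 is not broken down here. Compound 2 and compound 1 differ in a single place: hydrogen in place of methyl on an aromatic carbon That change produced a 7.8-fold higher number from compound 2 to compound 1 (0.89 log units; beyond the scatter). The same change, at the same place, leads from compound 3 to the not yet measured compound 4 `COc1cccc(-c2cc(O)c3cccnc3n2)c1`: hydrogen in place of methyl on an aromatic carbon Among the compounds shown, this is the only other pair in which it occurs. Because compound 3 sits at the limit of < 10 nM in this assay, at which 1 of the 3 values shown sits, its true value is not known, so the expectation for compound 4 rests on the measured step alone, and the step from compound 3 to compound 4 is expected to be an at least 3.0-fold higher number from compound 3 to compound 4 (0.47 log units; beyond the scatter). Compound 4 is accordingly estimated at 30 nM, with a likely range from 5 nM to 150 nM.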

Compound 4, concentration for 50% growth inhibition: < 10 nM
Compound 4: a limit, no number; the forecaster's own chance of this, stated with the estimate: 15%; middle value at least 3.0-fold (0.47 log units) away from the limit.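

In this assay compound 4 returns only a limit, which is < 10 nM. The step from compound 3 to compound 4 cannot be read, because both compounds stand at the same limit: the limit of < 10 nM in this assay, at which 2 of the 4 values shown sit. The compounds shown leave open whether replacing methyl with hydrogen changes growth inhibition at all when going from compound 3 to compound 4.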